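Working notes: the step from compound 3 to compound 4

This account rests on a few compounds, and the source may have more. Where it says the series, first, only, none or still open, it means among the compounds named here.

- compound 1 `O=C1c2c[n+]([O-])c3ccccc3c2C(=O)c2c1c1ccccc1n2Cc1cn([C@@H]2C[C@H](O)[C@@H](CO)O2)nn1` gives 150 nM in a functional assay on SH-SY5Y cells (Homo sapiens) for cytotoxicity, read by MTT assay, with a stated time of 72 h; on this read-out higher numbers stand for weaker inhibition and lower numbers for stronger inhibition
- compound 2 `O=C1c2c[n+]([O-])c3ccccc3c2C(=O)c2c1c1ccccc1n2Cc1cn(CC(O)CO)nn1` gives > 1000 nM in this assay (a limit of the assay)
- compound 3 `CCCCN1CCN(CCCCn2c3c(c4ccccc42)C(=O)c2c[n+]([O-])c4ccccc4c2C3=O)CC1` gives 6100 nM in this assay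

Of the two true numbers, compound 3 holds the higher one (6100 nM), against compound 1 (150 nM). Compound 2 cannot be ranked against them, since its entry is only a limit.

Compound 4 `CN(C)CCCCn1c2c(c3ccccc31)C(=O)c1c[n+]([O-])c3ccccc3c1C2=O` arises from compound 3 by one change dimethylamino in place of 4-butylpiperazin-1-yl on a saturated chain carbon, four bonds along the chain from an aromatic nitrogen on the side chain. Among the compounds with values here, no measured step covers this exchange. The only one, an at least 6.6-fold higher number from compound 1 to compound 2 (0.82 log units; beyond the scatter), lies on a different side chain and shows just that such an exchange can move the number beyond the scatter. Compound 3 stands at the top of the true numbers (6100 nM), so a moderate fall is expected rather than a further rise, with low confidence. The expected size is an estimated 3.1-fold lower number from compound 3 to compound 4 (0.48 log units; beyond the scatter) in this assay on this loose basis. Compound 4 is estimated at 2000 nM in this assay with expected bounds from 400 nM to 9000 nM on this read-out.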

Compound 4, half-maximal inhibitory concentration: 250 nM
Compound 4: the middle estimate sits 8.0-fold (0.90 log units) above what was measured, outside the stated range (below it).
By their numbers in this assay, from the lowest: compounds 1 and 4 (each within the scatter of the next); then compound 3.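

In this assay, the far end of the chain on the aromatic nitrogen proves highly sensitive: dimethylamino in place of 4-butylpiperazin-1-yl, four bonds along the chain from that nitrogen, gives a 24-fold lower number from compound 3 to compound 4 (1.39 log units; beyond the scatter). Compound 2 is held only as a limit of the assay: the limit of > 1000 nM in this assay, at which 1 of the 4 values shown sits. Against that limit, 3-(dimethylamino)propyl in place of 1-(2,3-dihydroxypropyl)-1H-1,2,3-triazol-4-yl still reads as an at least 4.0-fold lower number from compound 2 to compound 4 (0.60 log units; beyond the scatter), so this exchange extends the evidence for side-chain sensitivity beyond the triazole-bearing pair.

The compounds shown leave open whether the step follows the piperazine ring or its butyl group, a question that 4-methylpiperazin-1-yl, morpholin-4-yl or diethylamino at the same chain carbon would address. They also leave open how a longer chain carrying dimethylamino would behave.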